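Replacing the anilide aryl with a methoxybenzyl group

The compounds below may be only part of what the source reports. "The series", "measured", "known", "first", "only" and "open" are said of these compounds alone.

Compound 1 `COc1ccc2c(=O)c(/C=C/C(=O)Nc3ccc(C)cc3)coc2c1`: 39300 nM
Compound 2 `COc1ccc2c(=O)c(/C=C/C(=O)Nc3cc(C)ccc3C)coc2c1`: > 100000 nM
Compound 3 `COc1ccc2c(=O)c(/C=C/C(=O)Nc3ccc(Cl)cc3)coc2c1`: > 100000 nM

In a functional assay (QGY7701 cells, Homo sapiens) for inhibition, read by MTT assay, with a stated time of 48 h (a higher number here means a weaker inhibitor, a lower number a stronger inhibitor), compound 1 gives 39300 nM. Compound 2 reaches only the limit of this assay, > 100000 nM. Compound 3 likewise sits at the limit, > 100000 nM; the step of an at least 2.5-fold higher number from compound 1 to compound 3 (0.40 log units; beyond the scatter) is therefore readable only as a lower bound, and the step that the two limits leave unreadable from compound 2 to compound 3 cannot be read at all, as noted in the limit of > 100000 nM in this assay, at which 2 of the 3 values shown sit. Compound 4 `COc1ccc(CNC(=O)/C=C/c2coc3cc(OC)ccc3c2=O)cc1` carries the change (4-methoxybenzyl in place of 4-chlorophenyl on an amide-type nitrogen). Going by the values given here, no measured step covers an aryl-to-benzyl exchange on this nitrogen, so the steps of an at least 2.5-fold higher number from compound 1 to compound 2 (0.40 log units; beyond the scatter) and an at least 2.5-fold higher number from compound 1 to compound 3 (0.40 log units; beyond the scatter) merely show that both changes of the anilide so far weakened inhibition. Compound 4 is therefore expected to remain near the limit, estimated at 80000 nM (range 20000 nM to 300000 nM), a step of an at least 1.2-fold lower number from compound 3 to compound 4 (0.09 log units; that floor lies within the scatter).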

Compound 4, half-maximal inhibitory concentration: 15700 nM
For compound 4 the middle estimate is 5.1-fold (0.71 log units) above the measured one; the whole stated range lies above it.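

In this assay, an anilide aryl is not required on the amide-type nitrogen: 4-methoxybenzyl gives a 2.5-fold lower number from compound 1 to compound 4 (0.40 log units; beyond the scatter), the only change shown that strengthens inhibition. Against the two anilides that sit at a limit, it gives an at least 6.3-fold lower number from compound 3 to compound 4 (0.80 log units; beyond the scatter) and an at least 6.3-fold lower number from compound 2 to compound 4 (0.80 log units; beyond the scatter), and both steps are lower bounds only: the limit of > 100000 nM in this assay, at which 2 of the 4 values shown sit.

The compounds shown leave open whether the gain belongs to the benzyl link or to the methoxy group. They also leave open whether a longer chain, such as 2-phenylethyl, or a benzyl group carrying a dimethylamino group would go further.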